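Two Chlorines in Place of an Amine: What to Expect

The source may hold more compounds than are shown below. What is called first, only, known or untested is meant among the compounds shown, and "the series" means these compounds.

Compound 1 `COc1cc(-c2cc(/C=C/C(=O)c3ccc(N)cc3)[nH]n2)cc(OC)c1OC` was tested in a functional assay on MCF7 cells (Homo sapiens) for cytotoxicity, read by sulforhodamine B assay, with a stated time of 48 h, tested at 0.1 uM (a higher number here means a weaker effect of the compound at the concentration tested, a lower number a stronger effect), where compound 1 gives 91%. Compound 2 `COc1ccc(-c2cc(/C=C/C(=O)c3ccc(OC)c(OC)c3)[nH]n2)cc1` shares the same core and gives 88% in this assay, a number that lies within the usual scatter of the value of compound 1, so the two cannot be told apart on these data. Both values show that, at the concentration tested, the cells are affected only weakly.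

Compound 3 `COc1cc(-c2cc(/C=C/C(=O)c3ccc(Cl)c(Cl)c3)[nH]n2)cc(OC)c1OC` has not yet been measured. It differs from compound 1 in one place: 3,4-dichlorophenyl in place of 4-aminophenyl on a carbonyl carbon. Among the measured compounds shown here, no pair of measured compounds separated by a single change is available, so there is no measured step to lean on. The step of a number 3 percentage points lower from compound 1 to compound 3 (within the scatter) is expected to stay within the scatter, with no clear direction. Compound 3 is therefore estimated at 88%, in a range from 72% to 100%.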

Compound 3, a percentage reported as activity, at one concentration (the size of the read-out at that concentration, not a potency): 105%
Estimate against measurement, compound 3: 17 percentage points below; the measured number lies above the stated range.
By their numbers in this assay, from the lowest: compounds 2 and 1 (each within the scatter of the next); then compound 3.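

Replacing 4-aminophenyl with 3,4-dichlorophenyl on a carbonyl carbon gives a number 14 percentage points higher from compound 1 to compound 3 (beyond the scatter) in this assay, the first shift in these data that can be told apart from the usual scatter. What sits at this position can therefore change the read-out, and here the change points towards a weaker effect at the concentration tested. Among the compounds shown here, nothing measured so far explains this shift.

On these data alone, it remains open whether the shift comes from losing the amine or from gaining the two chlorines, and a plain phenyl or a 4-chlorophenyl on the same carbonyl carbon would help separate the two. Compound 1 already gives 91% at this single concentration, so these numbers cannot show how potent any of these compounds is.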